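The source may hold more compounds than are shown below. What is called first, only, known or untested is meant among the compounds shown, and "the series" means these compounds.

Compound 1 `Nc1ccc(/C=C/C(=O)Nc2nnc(-c3ccccc3)[nH]2)cc1` sits at the top of the three numbers from an ADME assay on Vero cells (Chlorocebus sabaeus) for cytotoxicity, read by MTT assay, with a stated time of 72 h (on this read-out lower numbers stand for higher toxicity in this test and higher numbers for lower toxicity in this test), where compound 1 gives 1910000 nM. Compound 2 `Cc1ccc(/C=C/C(=O)Nc2nnc(-c3ccccc3)[nH]2)cc1` gives 1760000 nM, and compound 3 `COc1ccc(/C=C/C(=O)Nc2nnc(-c3ccccc3)[nH]2)cc1OC` gives 1210000 nM; both lie within the scatter of compound 1, so no order among the three can be read. The move to compound 4 `O=C(/C=C/c1ccccc1)Nc1nnc(-c2ccccc2)[nH]1` is hydrogen in place of amino on an aromatic carbon. For the measured compounds named here, the only measured step touching this position, a 1.1-fold lower number from compound 1 to compound 2 (0.04 log units; within the scatter), replaced the amino without moving the number beyond the scatter. Going by the values given here, no step removing the group to hydrogen is available, so the expectation is taken from that one. The step from compound 1 to compound 4 is therefore expected to be a 1.1-fold lower number from compound 1 to compound 4 (0.05 log units; within the scatter), no change beyond the scatter. Compound 4 is estimated at 1700000 nM, within 900000 nM to 3200000 nM.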

Compound 4, half-maximal cytotoxic concentration: 1570000 nM
Estimate against measurement, compound 4: 1.1-fold (0.03 log units) above; the measured number falls inside the stated range.
By their numbers in this assay, from the lowest: compounds 3, 4, 2 and 1 (each within the scatter of the next).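

Hydrogen at this place gives a 1.2-fold lower number from compound 1 to compound 4 (0.09 log units; within the scatter) in this assay, so going from 4-aminophenyl to phenyl, with the substituent gone altogether, produces no readable change. Hydrogen in place of methyl gives a 1.1-fold lower number from compound 2 to compound 4 (0.05 log units; within the scatter), so amino, methyl and hydrogen on this aromatic carbon cannot be told apart in this test. Nothing available explains why these three replacements read alike.

Still open, on these data alone, is whether a carboxylic acid, a chlorine atom or a longer chain on this aromatic carbon would move the number beyond the scatter. Changes to the phenyl on the other side of the shared core also remain open.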